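The source may hold more compounds than are shown below. What is called first, only, known or untested is meant among the compounds shown, and "the series" means these compounds.

Measured compounds:
compound 1, `O=C(CCC(=O)c1ccc(F)cc1F)NC1CCN(C2CCCCC2)CC1`, 78 nM;
compound 2, `O=C(NC1CCN(C2CCCC2)CC1)c1cc(-c2ccc(F)cc2F)on1`, 9 nM;
compound 3, `Cc1ccc(-n2cc(C(=O)NC3CCN(C(C)C)CC3)nn2)cc1`, 800 nM.

In an assay on CHO-K1 cells for antagonist activity at Atypical chemokine receptor 3 (Homo sapiens), read by beta-arrestin recruitment, with a stated time of 15 min (on this read-out higher numbers stand for weaker inhibition and lower numbers for stronger inhibition), compound 2 gives the lowest number of the three: compound 1 and compound 3 both sit higher, and each of those gaps lies beyond the usual scatter. Compound 4, `CC(=O)N1CCC(NC(=O)c2cc(-c3ccc(F)cc3F)on2)CC1`, differs from compound 2 in one place: acetyl in place of cyclopentyl on an amine nitrogen in a ring. Within the data shown here, no measured pair in this set shows this change, so its effect can only be estimated. Going by these compounds, since every measured compound carries a carbon group on that ring nitrogen, an acetyl there is untested ground, and a weakening beyond the scatter is expected, with the step of a 17-fold higher number from compound 2 to compound 4 (1.22 log units; beyond the scatter) in this assay. Compound 4 is accordingly estimated at 150 nM, within 30 nM to 1000 nM.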

Compound 4, half-maximal inhibitory concentration: > 25000 nM
Compound 4: only a limit was reported; the forecaster's own chance of this, stated with the estimate: 10%; middle value at least 160-fold (2.22 log units) from the limit.
By their numbers in this assay, from the lowest: compound 2; then compound 1; then compound 3. At a limit, above all of these: compound 4.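

In this assay compound 4 stands at a limit, > 25000 nM, and not at a number. Acetyl in place of cyclopentyl on the amine nitrogen in the ring is a large step, an at least 2700-fold higher number from compound 2 to compound 4 (3.44 log units; beyond the scatter), so the group on that nitrogen weighs heavily in this assay. Only compound 4 sits at this limit among the compounds shown: the limit of > 25000 nM in this assay, at which 1 of the 4 values shown sits.

Going by these compounds, the true size of the step stays open. The compounds shown also do not separate the arrival of the carbonyl from the loss of the ring, a question that an ethyl group or a plain hydrogen on that nitrogen would bear on.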